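Trimming an isopropyl group to ethyl

This account rests on a few compounds, and the source may have more. Where it says the series, first, only, none or still open, it means among the compounds named here.

Compound 1 `CC(C)NC(=S)NC1CC(C)(C)Oc2ccc(Cl)cc21`: 57000 nM
Compound 2 `CC(C)NC(=O)NC1CC(C)(C)Oc2ccc(Cl)cc21`: 62000 nM

For the measured compounds named here, in a functional assay on U-373MG ATCC cells (Homo sapiens) for inhibition, read by MTT assay, with a stated time of 72 h (a higher number here means a weaker inhibitor, a lower number a stronger inhibitor), compound 2 sits level with compound 1, as the only measured step shows (a 1.1-fold higher number from compound 1 to compound 2 (0.04 log units; within the scatter)). The next compound is compound 3 `CCNC(=O)NC1CC(C)(C)Oc2ccc(Cl)cc21`, in which isopropyl becomes ethyl (hydrogen in place of methyl on a saturated chain carbon bound to an amide-type nitrogen and a saturated chain carbon). That measured step exchanges sulfur for oxygen and leaves the isopropyl group untouched, so it bears on this change only indirectly. It shows a swap elsewhere in the group on the amine nitrogen passing within the scatter, but no measurement tests the length of this chain. The expectation therefore rests on compound 2 (62000 nM), and no shift beyond the scatter is expected (a 1.0-fold lower number from compound 2 to compound 3 (0.01 log units; within the scatter)). Compound 3 is estimated at 60000 nM in this assay (expected range 30000 nM to 110000 nM).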

Compound 3, half-maximal inhibitory concentration: > 100000 nM
Compound 3: a limit, no number; the forecaster's own chance of this, stated with the estimate: 10%; middle value at least 1.6-fold (0.22 log units) from the limit.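

Compound 3 gives a limit in this assay, not a number: the limit of > 100000 nM in this assay, at which 1 of the 3 values shown sits.

Trimming isopropyl to ethyl gives an at least 1.6-fold higher number from compound 2 to compound 3 (0.20 log units; that floor lies within the scatter), and replacing the whole group on the amine nitrogen gives an at least 1.7-fold higher number from compound 1 to compound 3 (0.24 log units; that floor lies within the scatter). Unlike the exchange of sulfur for oxygen, these steps touch the chain itself, and they show that the ethyl compound gives no number here, although neither floor establishes a shift beyond the scatter and the true size of the steps remains unknown.

The compounds shown leave open how a longer chain such as n-butyl, or a ring such as cyclopropyl, would read at this place. They also leave open whether an ethyl chain with sulfur in place of the carbonyl oxygen would give a number or a limit.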